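The source may hold more compounds than are shown below. What is called first, only, known or untested is meant among the compounds shown, and "the series" means these compounds.

Compound 1 `O=c1c2ccccc2c(Nc2n[nH]c3ccccc23)nn1-c1ccccc1` was entered in a functional assay on HCT-116 cells (Homo sapiens) for cytotoxicity, read by CellTiter-Glo, with a stated time of 5 days (on this read-out higher numbers stand for weaker inhibition and lower numbers for stronger inhibition), where compound 1 is recorded as "not determined" (no result reported), so it contributes no number here. For the measured compounds named here, compound 2 `Cc1cc(Nc2nn(Cc3cc(F)ccc3F)c(=O)c3ccccc23)n[nH]1` gives 570 nM in this assay and is the only measured value shown. Compound 3 `Cc1cc(Nc2nn(Cc3ccncc3)c(=O)c3ccccc23)n[nH]1` differs from compound 2 in one place: pyridin-4-yl in place of 2,5-difluorophenyl on a saturated chain carbon bound to an aromatic nitrogen. Going by the values given here, no step between two measured compounds is available to guide this change. A modest weakening of inhibition, somewhat beyond the usual scatter, is expected, as a 2.1-fold higher number from compound 2 to compound 3 (0.32 log units; beyond the scatter). Compound 3 is therefore estimated at 1200 nM in this assay, within a range of 400 nM to 4000 nM.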

Compound 3, half-maximal inhibitory concentration: 20200 nM
Beside the measured number, compound 3's estimate is 17-fold (1.23 log units) below it, outside the stated range (above it).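

The position on a saturated chain carbon bound to an aromatic nitrogen proves highly sensitive to which ring it carries: pyridin-4-yl in place of 2,5-difluorophenyl gives a 35-fold higher number from compound 2 to compound 3 (1.55 log units; beyond the scatter) in this assay and marks a large loss of inhibition. A single change here can therefore decide much of the activity of compounds on this core. Nothing measured here explains the loss. Going by these compounds, the change swaps a ring nitrogen in and both fluorines out together, so their separate contributions remain open. On these data alone, a plain benzyl group would stand between the two, and how it would behave remains unknown.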